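Replacing a bromo group by isopropyl in an agonist series

A few compounds are considered here, and "the series" means these few. Any claim that something is new, unique, unknown or untested is made for them only; others in the source may bear on it.

Compound 1: `N#Cc1ccc(-c2nc3sccn3c2/C=N/OCc2ccc(Cl)c(Cl)c2)cc1`, 3400 nM
Compound 2: `Clc1ccc(CO/N=C/c2c(-c3cccc4ccccc34)nc3sccn23)cc1Cl`, 940 nM
Compound 3: `Clc1ccc(CO/N=C/c2c(-c3ccc(Br)cc3)nc3sccn23)cc1Cl`, 480 nM

All three were measured in an assay on HepG2 cells for agonist activity at nuclear receptor subfamily 1 group I member 3 (Homo sapiens), read by a luciferase reporter, with a stated time of 23 h; a lower number here means that less compound is needed, a higher number that more compound is needed for the effect. Compound 3 stands at the low end of the three numbers: one of its gaps (a 2.0-fold lower number from compound 2 to compound 3 (0.29 log units; within the scatter)) is within the scatter, while the other (a 7.1-fold lower number from compound 1 to compound 3 (0.85 log units; beyond the scatter)) is beyond it.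

Compound 4, `CC(C)c1ccc(-c2nc3sccn3c2/C=N/OCc2ccc(Cl)c(Cl)c2)cc1`, differs from compound 3 by isopropyl in place of bromo on an aromatic carbon. Going by the values given here, the only measured step at this position is the exchange of cyano for bromo, a 7.1-fold lower number from compound 1 to compound 3 (0.85 log units; beyond the scatter); no measured compound carries an isopropyl group, so the direction of the new step is open. The step from compound 3 to compound 4 is expected to be small, a 1.5-fold higher number from compound 3 to compound 4 (0.16 log units; within the scatter). Compound 4 is estimated at 700 nM, with a range from 250 nM to 2000 nM.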

Compound 4, half-maximal effective concentration: 590 nM
Estimate against measurement, compound 4: 1.2-fold (0.07 log units) above, and the stated range covers the measured number.
By their numbers in this assay, from the lowest: compounds 3, 4 and 2 (each within the scatter of the next); then compound 1.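

In this assay, isopropyl, with its 3 carbon atoms, replaces the single bromine atom on the ring with no change that stands out from the scatter (a 1.2-fold higher number from compound 3 to compound 4 (0.09 log units; within the scatter)). Compound 4 is also not separated from the naphthalen-1-yl compound (a 1.6-fold lower number from compound 2 to compound 4 (0.20 log units; within the scatter)), but it remains clearly apart from the cyano compound (a 5.8-fold lower number from compound 1 to compound 4 (0.76 log units; beyond the scatter)). Among these four compounds, only cyano stands apart, and no order can be drawn among the other three groups. As far as these compounds go, whether an amine, a carboxylic acid or a longer chain at this position would fit the same picture stays open. Nothing available explains why these groups give such numbers.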